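The compounds below may be only part of what the source reports. "The series", "measured", "known", "first", "only" and "open" are said of these compounds alone.

Compound 1 `CC(Oc1ccc(Oc2ccc(F)cc2)cc1)C(=O)Cn1nnc(-c2ccc(Cl)cc2)n1`: 42 nM
Compound 2 `CC(Oc1ccc(-c2ccccc2)cc1)C(=O)Cn1nnc(-c2ccc(Cl)cc2)n1`: 25 nM

Two compounds were measured in an assay on microsomes from brain for inhibition of Fatty-acid amide hydrolase 1 (Rattus norvegicus), read by fluorescence and HPLC, with a stated time of 60 min; a lower number here means a stronger inhibitor, a higher number a weaker inhibitor. Compound 1 gives 42 nM there, and compound 2 gives 25 nM. Among the measured compounds shown here, the one step that links them, a 1.7-fold lower number from compound 1 to compound 2 (0.23 log units; within the scatter), is within the scatter. Compound 2 therefore stands at the low end of the two numbers, but since its step from compound 1 does not exceed the scatter, the two compounds cannot be ranked against each other.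

Compound 3 `CC(Oc1ccc(-c2ccccc2)cc1)C(=O)Cn1nnc(-c2ccc(C(=O)O)cc2)n1` keeps the core of compound 2 and differs from it by carboxy in place of chloro on an aromatic carbon. For the measured compounds named here, the only measured step concerns the other end of the molecule, so no measured step bears on this change, and the data give no direct guide to its size or direction. Without such a guide, a weaker inhibitor is expected, with a wide margin of uncertainty. Compound 3 is estimated to give 125 nM, within a range from 30 nM to 600 nM. The expected step is a 5.0-fold higher number from compound 2 to compound 3 (0.70 log units; beyond the scatter).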

Compound 3, half-maximal inhibitory concentration: 83 nM
The estimate for compound 3 lay 1.5-fold (0.18 log units) above the measured number; measured number inside the range.
By their numbers in this assay, from the lowest: compounds 2, 1 and 3 (each within the scatter of the next, the first and the last beyond it).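

Among the compounds shown here, the earlier compounds varied only the other end of the molecule, so this is the first reading of the position para to a large group on the chlorophenyl side. In this assay, carboxy in place of chloro gives a 3.3-fold higher number from compound 2 to compound 3 (0.52 log units; beyond the scatter), a modest step that lies beyond the scatter. The position therefore responds to this change, yet a group with more heavy atoms, a hydrogen-bond donor and a hydrogen-bond acceptor, where chloro has none of these, still leaves compound 3 at 83 nM, and nothing measured here explains the size of the step.

A single replacement at this position cannot show whether the step belongs to carboxy in particular or would also appear with a methyl ester, a primary amide, an amine or a longer chain ending in a carboxylic acid. As far as these compounds go, it also remains open whether carboxy would have a step of similar size and direction if the 4-fluorophenoxy group of compound 1 stood at the other end of the molecule in place of phenyl.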